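Homologating the acyl chain of a methoxyphenylbutyl amide

The source may hold more compounds than are shown below. What is called first, only, known or untested is meant among the compounds shown, and "the series" means these compounds.

Compound 1: `COc1cccc(CCCNC(C)=O)c1`, 63 nM
Compound 2: `COc1ccc(CCCNC(C)=O)cc1`, 14000 nM
Compound 3: `CCC(=O)NCCCCc1cccc(OC)c1`, 119 nM

Three amides have been measured in an assay for binding affinity to melatonin receptor (Gallus gallus); a lower number here means a stronger inhibitor, a higher number a weaker inhibitor. Compound 1 gives 63 nM in this assay, while compound 2, which carries its methoxy group at a different ring position, gives 14000 nM. Compound 3 gives 119 nM in this assay. Its value and that of compound 1 lie within the scatter of each other, so no order between them can be claimed. Against compound 2, compound 3 shows a much lower number, a gap well beyond the scatter.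

The next compound, compound 4 (`CCCC(=O)NCCCCc1cccc(OC)c1`), differs from compound 3 by a single change: methyl in place of hydrogen on a saturated chain carbon, two bonds along the chain from a carbonyl carbon. Going by the values given here, no measured pair in this set shows this kind of change, so its effect in this assay has to be estimated from the general spread of the three numbers rather than from a direct precedent. Given that the lengthening of the acyl chain is a small change on the amide end, the step in this assay from compound 3 to compound 4 is expected to be a 1.3-fold higher number from compound 3 to compound 4 (0.13 log units; within the scatter), that is, no step beyond the scatter or at most a slightly higher number. Compound 4 is therefore estimated to give 160 nM in this assay, with a range from 50 nM to 500 nM.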

Compound 4, inhibition constant: 208 nM
Compound 4: the middle estimate sits 1.3-fold (0.11 log units) below what was measured; low and high end bracket the measured number.
By their numbers in this assay, from the lowest: compounds 1, 3 and 4 (each within the scatter of the next, the first and the last beyond it); then compound 2.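

In this assay, putting methyl in place of hydrogen on a saturated chain carbon, two bonds along the chain from a carbonyl carbon, gives a 1.7-fold higher number from compound 3 to compound 4 (0.24 log units; within the scatter) and so leaves the propanoyl and propylcarbonyl amides indistinguishable in this assay. Going by these compounds alone, this is the first pair in the set that differs in one place only, so it gives the first direct reading for this position: this single added methyl produces no step beyond the scatter. Nothing available here accounts for the size of this step, and one pair cannot show a trend along the acyl chain.

On these data alone, it remains open whether a longer chain such as pentanoyl, a branched isopropyl group or a cyclopropyl ring on the carbonyl would also stay within the scatter of compound 3, or whether a hydroxyl or an amine on the same chain carbon would produce a clear step. As far as these compounds go, it is also open whether the same change would give a comparable step on the core of compound 2, which carries its methoxy group at a different ring position.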